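The source may hold more compounds than are shown below. What is called first, only, known or untested is meant among the compounds shown, and "the series" means these compounds.

Compounds measured so far:
- compound 1 `CNc1nc(N)nc2c1ncn2/C=C1/CC1(CO)CO`: 265000 nM
- compound 2 `Nc1nc(NCc2ccccc2)c2ncn(/C=C3/CC3(CO)CO)c2n1`: > 300000 nM
- compound 3 `CCCCCCSc1nc(N)nc2c1ncn2/C=C1/CC1(CO)CO`: > 300000 nM

For the measured compounds named here, in an ADME assay on HFF cells (Homo sapiens) for cytotoxicity, with a stated time of 8 days (on this read-out lower numbers stand for higher toxicity in this test and higher numbers for lower toxicity in this test), compound 1 gives 265000 nM, and it is the only compound of the three for which a number rather than a limit is reported. For compound 2 the result is a limit of the assay, > 300000 nM. For compound 3 the result is likewise a limit, > 300000 nM. Compound 4 `CCCOc1nc(N)nc2c1ncn2/C=C1/CC1(CO)CO` has not yet been measured; it differs from compound 1 as follows.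

propoxy in place of methylamino on an aromatic carbon

Going by the values given here, two measured steps bear on a change at this position of the shared core. The step of an at least 1.1-fold higher number from compound 1 to compound 2 (0.05 log units; that floor lies within the scatter) and the step of an at least 1.1-fold higher number from compound 1 to compound 3 (0.05 log units; that floor lies within the scatter) both point upward, but only as floors, and both end at the limit of > 300000 nM in this assay, at which 2 of the 3 values shown sit. The step that the two limits leave unreadable from compound 2 to compound 3 cannot be read. The expectation for compound 4 is therefore a step of no readable size beyond the scatter, most likely ending at the same limit. Compound 4 is estimated at 300000 nM in this assay, in the range 150000 nM to 600000 nM, which means an expected step of a 1.1-fold higher number from compound 1 to compound 4 (0.05 log units; within the scatter).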

Compound 4, half-maximal cytotoxic concentration: > 300000 nM
Compound 4: a limit, no number; the forecaster's own chance of this, stated with the estimate: 60%; the middle value sits exactly at the limit.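

In this assay, propoxy in place of methylamino gives an at least 1.1-fold higher number from compound 1 to compound 4 (0.05 log units; that floor lies within the scatter), so this change on the aromatic carbon cannot be told apart from the scatter. An oxygen-linked chain now stands at this place alongside the nitrogen-linked benzylamino of compound 2 and the sulfur-linked hexylsulfanyl of compound 3, and all three compounds end at the same ceiling: the limit of > 300000 nM in this assay, at which 3 of the 4 values shown sit. The steps among compound 2, compound 3 and compound 4 cannot be read, as each of these compounds gives only a limit.

On these data alone, how these three compounds truly rank against one another stays open, as does whether any replacement of methylamino here moves the read-out beyond the scatter. The compounds shown also leave open what a carboxylic acid or a basic amine at the end of a longer chain would do on this aromatic carbon.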